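Swapping one open-chain amine for another on a fused core

The compounds below may be only part of what the source reports. "The series", "measured", "known", "first", "only" and "open" are said of these compounds alone.

Of the compounds shown here, three sharing one core have been measured in an assay on cell membranes for displacement of a labelled ligand from corticotropin-releasing factor receptor 1 (Rattus norvegicus); a higher number here means a weaker inhibitor, a lower number a stronger inhibitor. Compound 1 `CCOCC(COCC)Nc1nc(C)nc2c(-c3ccc(OC)cc3C)c(C)nn12` gives 19.3 nM; compound 2 `COc1ccc(-c2c(C)nn3c(N4CCCC4)nc(C)nc23)c(C)c1` gives 80.7 nM; compound 3 `CCCCN(CC)c1nc(C)nc2c(-c3ccc(OC)cc3C)c(C)nn12` gives 2.3 nM. Compound 3 therefore stands lowest of the three, and its steps to both others lie beyond the scatter. The amine attached to the core drives these numbers: a 4.2-fold higher number from compound 1 to compound 2 (0.62 log units; beyond the scatter), an 8.4-fold lower number from compound 1 to compound 3 (0.92 log units; beyond the scatter), and a 35-fold lower number from compound 2 to compound 3 (1.55 log units; beyond the scatter).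

Compound 4 `CCCN(CC1CC1)c1nc(C)nc2c(-c3ccc(OC)cc3C)c(C)nn12` is not yet measured. It keeps the core of compound 3 and changes only that amine: (cyclopropylmethyl)(propyl)amino in place of butyl(ethyl)amino on an aromatic carbon. The leaving and entering groups are both dialkylamines of nearly the same count of heavy atoms, whereas the ring-closed amine of compound 2 sits far higher, as a 35-fold lower number from compound 2 to compound 3 (1.55 log units; beyond the scatter) shows. Among the compounds with values here, no measured step covers this exact swap, so the large step in a 35-fold lower number from compound 2 to compound 3 (1.55 log units; beyond the scatter) mainly tells how sensitive this position is, while the present change is much smaller in kind. The expected step is a 1.2-fold lower number from compound 3 to compound 4 (0.06 log units; within the scatter), within or close to the scatter. Compound 4 is estimated at 2 nM, with a range from 0.7 nM to 6 nM.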

Compound 4, half-maximal inhibitory concentration: 1.96 nM
The estimate for compound 4 lay 1.0-fold (0.01 log units) above the measured number; the measured number falls inside the stated range.
By their numbers in this assay, from the lowest: compounds 4 and 3 (each within the scatter of the next); then compound 1; then compound 2.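

In this assay, a 1.2-fold lower number from compound 3 to compound 4 (0.07 log units; within the scatter) shows that this position accepts a three-membered carbon ring on the open-chain amine without a change that can be told from the scatter. The position is still sensitive to other amines, with a 41-fold lower number from compound 2 to compound 4 (1.61 log units; beyond the scatter) and a 9.8-fold lower number from compound 1 to compound 4 (0.99 log units; beyond the scatter) for the new amine, so that sensitivity does not extend to a swap between these two open-chain dialkylamines. Nothing measured beyond these numbers bears on the result.

As far as these compounds go, how far this tolerance runs remains open: a longer chain such as hexyl, or a larger ring such as cyclohexylmethyl, might behave differently on the same nitrogen. From the compounds shown here alone, it is also open whether piperidin-1-yl, a ring amine one carbon larger than pyrrolidin-1-yl, would sit with the open-chain amines or with the pyrrolidine.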